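The source may hold more compounds than are shown below. What is called first, only, known or untested is meant among the compounds shown, and "the series" means these compounds.

In a functional assay on isolated protein for inhibition of Glucose-dependent insulinotropic receptor (Rattus norvegicus), read by HTRF and cAMP accumulation (on this read-out higher numbers stand for larger maximal responses and lower numbers for smaller maximal responses), compound 1 `Cc1nc(S(C)(=O)=O)ccc1Oc1ncnc(OC2CCN(C(=O)OC(C)C)CC2)c1F` gives 77% and compound 2 `Cc1nc(S(C)(=O)=O)ccc1Oc1ncnc(OC2CCN(C(=O)OC(C)(C)CF)CC2)c1F` gives 95%, the highest of the two numbers shown; the step of a number 18 percentage points higher from compound 1 to compound 2 (beyond the scatter) is the only measured one. Compound 3 `Cc1nc(S(C)(=O)=O)ccc1Oc1ncnc(OC2CCN(C(=O)OC(C)F)CC2)c1F` differs from compound 2 by 1-fluoroethyl in place of 1-(fluoromethyl)-1-methylethyl on an oxygen next to a carbonyl group, which keeps a fluorine on the chain but not the two extra carbons. The earlier step bears only indirectly; a drop of moderate size in this assay, or none beyond the scatter, is expected. For compound 3 the estimate is 85% (range 70% to 98%), a step of a number 10 percentage points lower from compound 2 to compound 3 (within the scatter) expected.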

Compound 3, largest response reached (reported as efficacy), in percent of the reference or control that the assay uses: 68%
Beside the measured number, compound 3's estimate is 17 percentage points above it; measured number below the stated range.
By their numbers in this assay, from the lowest: compounds 3 and 1 (each within the scatter of the next); then compound 2.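

In this assay, 1-fluoroethyl in place of 1-(fluoromethyl)-1-methylethyl on an oxygen next to a carbonyl group gives a number 27 percentage points lower from compound 2 to compound 3 (beyond the scatter). A fluorine on the chain is thus not enough to hold the response of compound 2, and fluoro in place of methyl gives a number 9 percentage points lower from compound 1 to compound 3 (within the scatter). No measurement shown accounts for these steps. From the compounds shown here alone, whether the response of compound 2 needs the fluorine, the larger chain or both stays open. A tert-butyl group on the same oxygen would separate these.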